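The compounds below may be only part of what the source reports. "The series", "measured", "known", "first", "only" and "open" are said of these compounds alone.

Compound 3 `O=C(Nc1cccc(-c2ncc[nH]2)c1)N1CCC(Oc2ccccc2Cl)CC1` gives 10 nM in an assay on isolated protein for inhibition of acyl-CoA desaturase 1 (Mus musculus) (on this read-out higher numbers stand for weaker inhibition and lower numbers for stronger inhibition), the lowest of the three numbers seen so far. Compound 1 `CNC(=O)c1cccc(NC(=O)N2CCC(Oc3ccccc3OC)CC2)c1` gives 81 nM in this assay. Compound 2 `O=C(Nc1ccccc1)N1CCC(Oc2ccccc2Cl)CC1` gives 590 nM in this assay. Going by the values given here, the only one-place step measured is a 59-fold lower number from compound 2 to compound 3 (1.77 log units; beyond the scatter), a large gain on adding the five-membered ring. Compound 4 `CC(C)(C)NC(=O)c1cccc(NC(=O)N2CCC(Oc3ccccc3Cl)CC2)c1` differs from compound 3 by (tert-butyl)carbamoyl in place of 1H-imidazol-2-yl on an aromatic carbon. Among the compounds with values here, no measured step swaps one group for another at this place; compound 1 carries a carbamoyl group, with a methoxy rather than a chloro ether, and stands above compound 3 yet well below compound 2, so a moderate loss against compound 3 is expected rather than a return to the unsubstituted level. Compound 4 is therefore expected to give 50 nM in this assay, within 15 nM to 200 nM, the expected step being a 5.0-fold higher number from compound 3 to compound 4 (0.70 log units; beyond the scatter).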

Compound 4, half-maximal inhibitory concentration: > 10000 nM
Compound 4: a limit, no number; the forecaster's own chance of this, stated with the estimate: 3%; middle value at least 200-fold (2.30 log units) from the limit.
By their numbers in this assay, from the lowest: compound 3; then compound 1; then compound 2. At a limit, above all of these: compound 4.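

Compound 4 stands at a limit of this assay, not at a number: the limit of > 10000 nM in this assay, at which 1 of the 4 values shown sits.

With an at least 1000-fold higher number from compound 3 to compound 4 (3.00 log units; beyond the scatter), this place on the aromatic ring proves not to accept every group with the same hydrogen-bond donor and acceptor counts as 1H-imidazol-2-yl. With an at least 16-fold higher number from compound 2 to compound 4 (1.22 log units; beyond the scatter), (tert-butyl)carbamoyl ends weaker than plain hydrogen, so a group here can lose as well as gain.

Still open, on these data alone, is whether the loss follows from the tert-butyl part or from the amide itself. An unsubstituted carbamoyl, an amine or a carboxylic acid at this place, on the chloro ether core, would separate these.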